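The compounds below may be only part of what the source reports. "The series", "measured", "known", "first", "only" and "open" are said of these compounds alone.

Measured compounds:
compound 1, `COc1ccccc1C1CC(C)=NN1C(=O)CN1CCC(OC)CC1`: 27200 nM
compound 2, `O=C(c1ccccc1)N1N=C(c2cc3ccccc3oc2=O)CC1c1ccccc1`: 5870 nM

Of the compounds shown here, two have been tested in a functional assay on PC-3 cells (Homo sapiens) for cytotoxicity, read by MTT assay, with a stated time of 48 h; on this read-out lower numbers stand for stronger inhibition and higher numbers for weaker inhibition. Compound 1 gives 27200 nM, while compound 2 gives 5870 nM, the lowest of the two numbers; the gap between these two values lies beyond the usual scatter, so compound 2 stands as the stronger of the two. The two share little beyond a carbonyl on a five-membered ring, so nothing can be read from this pair about single changes.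

Compound 3, `Cc1ccc(C(=O)N2N=C(c3cc4ccccc4oc3=O)CC2c2ccccc2)cc1`, keeps the whole core of compound 2 and differs from it in one spot: methyl in place of hydrogen on an aromatic carbon, a methyl in place of hydrogen on an aromatic carbon, placed para to a large group, turning a benzoyl into a (4-methylphenyl)carbonyl. Within the data shown here, no measured pair shows what such a change does here. A single methyl on an otherwise unchanged molecule is usually a small step, in either direction or none beyond the scatter. For compound 3 the estimate is therefore 5000 nM, within 1800 nM to 15000 nM. The expected step from compound 2 to compound 3 is a 1.2-fold lower number from compound 2 to compound 3 (0.07 log units; within the scatter), essentially flat.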

Compound 3, half-maximal inhibitory concentration: 13200 nM
Estimate against measurement, compound 3: 2.6-fold (0.42 log units) below; measured number inside the range.
By their numbers in this assay, from the lowest: compound 2; then compound 3; then compound 1.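

In this assay, the change from phenyl to 4-methylphenyl, which turns the benzoyl of compound 2 into the (4-methylphenyl)carbonyl of compound 3, gives a 2.2-fold higher number from compound 2 to compound 3 (0.35 log units; beyond the scatter) and so weakens the effect on these cells. Among these compounds, this is the first comparison here in which the two compounds differ in one place only, and it shows that this position on the six-membered aromatic ring is not indifferent: a methyl in place of hydrogen is enough to produce a modest loss of activity on the otherwise unchanged molecule. Nothing available accounts for this loss, so the step stands as an observation without an explanation.

The compounds shown leave open whether the loss is particular to methyl or would also follow from another group at the same position, such as a methoxy, a chlorine atom or an amine. They also leave open whether a methyl elsewhere on the same ring would behave the same way, and whether the step would carry over to the core of compound 1.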